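Sulfonyl aryl swap in a shared-core sulfonamide series

The source may report more compounds than this note shows. Statements on the series, on what has been measured and on what is new or still open speak of the compounds shown alone.

Working notes on the series. Within the data shown here, in an assay on cells for inhibition of HSP60/HSP10 (Homo sapiens), with a stated time of 60 min (on this read-out lower numbers stand for stronger inhibition and higher numbers for weaker inhibition), compound 2 `O=S(=O)(Nc1ccc2oc(-c3ccccc3)nc2c1)c1ccccc1O` gives 85000 nM, which is the only number recorded so far. Compound 1 `O=S(=O)(Nc1ccc2oc(-c3ccccc3)nc2c1)c1ccc(Cl)c(C(F)(F)F)c1` returns only a limit of the assay, > 100000 nM. That limit is the limit of > 100000 nM in this assay, at which 1 of the 2 values shown sits. Compound 3 `O=S(=O)(Nc1ccc2oc(-c3ccccc3)nc2c1)c1ccc(Cl)c(Cl)c1` has not yet been measured.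

The change from compound 2 to compound 3 is 3,4-dichlorophenyl in place of 2-hydroxyphenyl on a sulfonyl sulfur. Among the measured compounds shown here, no measured step between two compounds is available, so the expectation rests on the two values shown: compound 2 holds the one number, while compound 1, which also carries chlorine on its sulfonyl aryl ring, sits at the limit of > 100000 nM in this assay, at which 1 of the 2 values shown sits. The step expected on this basis is a 1.8-fold higher number from compound 2 to compound 3 (0.25 log units; within the scatter), in the direction of weaker inhibition and beyond the usual scatter. Compound 3 is estimated at 150000 nM, in the range 50000 nM to 400000 nM, with a fair chance that this assay again reports only a limit.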

Compound 3, half-maximal inhibitory concentration: > 100000 nM
Compound 3: no number, only a limit; the forecaster's own chance of this, stated with the estimate: 60%; the middle value lies beyond the limit too.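

In this assay, 3,4-dichlorophenyl in place of 2-hydroxyphenyl on a sulfonyl sulfur gives an at least 1.1-fold higher number from compound 2 to compound 3 (0.07 log units; that floor lies within the scatter), so this change offers only a floor and does not establish weaker inhibition. The step between compound 1 and compound 3, chloro in place of trifluoromethyl on an aromatic carbon, cannot be read, since both compounds return only a limit. With compound 3, both sulfonyl aryl rings that carry chlorine sit at the limit, and compound 2 keeps the only number in the series: the limit of > 100000 nM in this assay, at which 2 of the 3 values shown sit.

What the compounds shown leave open is how far the sulfonyl aryl ring can move the read-out in either direction. A ring carrying an amine or a carboxylic acid in place of the hydroxy group of compound 2 would test whether any number can be obtained well clear of the limit.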